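The source may report more compounds than this note shows. Statements on the series, on what has been measured and on what is new or still open speak of the compounds shown alone.

Compound 1 `Cc1ccc(Oc2ccc(C#N)cc2S(=O)(=O)NC(=O)NC(C)(C)C)cc1` gives 750 nM in a functional assay on HEK293 cells for antagonist activity at thromboxane A2 receptor (Homo sapiens), read by fluorescence and calcium flux (a higher number here means a weaker inhibitor, a lower number a stronger inhibitor), the lowest of the three numbers recorded. Compound 2 `CCCCCNC(=O)NS(=O)(=O)c1cc(C#N)ccc1Oc1ccc(C)cc1` gives 900 nM, and the step of a 1.2-fold higher number from compound 1 to compound 2 (0.08 log units; within the scatter) lies within the scatter. Compound 3 `CCCCCNC(=O)NS(=O)(=O)c1cc(C#N)ccc1Oc1ccc(F)cc1` gives 9430 nM, and the step of a 10-fold higher number from compound 2 to compound 3 (1.02 log units; beyond the scatter) is large. Compound 4 `Cc1ccc(Nc2ccc(C#N)cc2S(=O)(=O)NC(=O)NC(C)(C)C)cc1` differs from compound 1 by (4-methylphenyl)amino in place of 4-methylphenoxy on an aromatic carbon. Neither measured step alters this part of the structure: one changes the group on the amide-type nitrogen, the other exchanges a methyl for a fluoro. Among the measured compounds shown here, no measured step therefore speaks directly to this change, and the expectation is only a modest rise in this assay, a 2.0-fold higher number from compound 1 to compound 4 (0.30 log units; within the scatter). Compound 4 is thus estimated at 1500 nM, within a range of 400 nM to 6000 nM.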

Compound 4, half-maximal inhibitory concentration: 850 nM
Compound 4: middle estimate off by 1.8-fold (0.25 log units), on the high side; low and high end bracket the measured number.
By their numbers in this assay, from the lowest: compounds 1, 4 and 2 (each within the scatter of the next); then compound 3.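

In this assay, (4-methylphenyl)amino in place of 4-methylphenoxy gives a 1.1-fold higher number from compound 1 to compound 4 (0.05 log units; within the scatter) and so, on this aromatic carbon, the two groups cannot be told apart. The entering group has a hydrogen-bond donor that the leaving group lacks, yet this adds no readable difference to the number. Nothing available explains this match.

Still open, from the compounds shown here alone, is whether a sulfur or methylene link would serve as well as the oxygen or nitrogen. Also open, going by these compounds, is whether the same exchange holds up when the tert-butyl group is replaced by pentyl.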